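Chloro to methoxy on a second hydrazone core

The source may hold more compounds than are shown below. What is called first, only, known or untested is meant among the compounds shown, and "the series" means these compounds.

Compound 1 `O=C(N/N=C/c1ccco1)c1cc(-c2ccc(Cl)cc2)nn1Cc1ccc(Cl)nc1` and compound 2 `COc1ccc(-c2cc(C(=O)N/N=C/c3ccco3)n(Cc3ccc(Cl)nc3)n2)cc1` share one core and differ in a single place: methoxy in place of chloro on an aromatic carbon. In a physicochemical assay on A549 cells for solubility, read by microscopy, with a stated time of 24 h (a lower number here means a stronger inhibitor, a higher number a weaker inhibitor), compound 1 gives 9820 nM, and compound 2 gives 15800 nM; the step is a 1.6-fold higher number from compound 1 to compound 2 (0.21 log units; within the scatter). Compound 3 `O=C(N/N=C/c1ccccc1O)c1cc(-c2ccc(Cl)cc2)nn1Cc1ccccc1` is built on another core, and the difference between the two cores is not broken down here. In this assay compound 3 gives 680 nM, the lowest of the three measured numbers, and its gaps to compound 1 and to compound 2 both lie beyond the scatter. Compound 4 `COc1ccc(-c2cc(C(=O)N/N=C/c3ccccc3O)n(Cc3ccccc3)n2)cc1` has not yet been measured. It differs from compound 3 in the same way that compound 2 differs from compound 1: methoxy in place of chloro on an aromatic carbon. The place reads the same word for word in both pairs, so this is the same change carried onto the second core. The expected step is a 1.5-fold higher number from compound 3 to compound 4 (0.17 log units; within the scatter), a size that rests on the measured step of a 1.6-fold higher number from compound 1 to compound 2 (0.21 log units; within the scatter). For compound 4 in this assay the estimate is 1000 nM, with a likely range from 450 nM to 2500 nM.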

Compound 4, half-maximal inhibitory concentration: 840 nM
Compound 4: middle estimate off by 1.2-fold (0.08 log units), on the high side; measured number inside the range.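

In this assay methoxy in place of chloro on the second core gives a 1.2-fold higher number from compound 3 to compound 4 (0.09 log units; within the scatter) and the same change on the first core gives a 1.6-fold higher number from compound 1 to compound 2 (0.21 log units; within the scatter) and so both steps lie within the scatter. For these two pairs alone, then, 4-chlorophenyl to 4-methoxyphenyl carries from one core to the other without a step beyond the scatter, but two pairs do not show that this would hold on a further core or in a different assay. Nothing available bears on the cause of this result.

The compounds shown leave open how an amine, a carboxylic acid or a longer chain such as ethoxy would read in the place of the chloro on either core. Also open, from the compounds shown here alone, is whether a group of that kind would give a step beyond the scatter on one core and not on the other, which these two pairs cannot settle.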